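The compounds below may be only part of what the source reports. "The series", "measured", "known", "first", "only" and "open" are said of these compounds alone.

Measured in an ADME assay on L6 cells (Rattus norvegicus) for cytotoxicity, read by resazurin assay; on this read-out higher numbers stand for weaker inhibition and lower numbers for stronger inhibition:
compound 1, `N=C(N)c1ccc2[nH]c(-c3ccc4nc(-c5ccc(F)cc5)[nH]c4c3)nc2c1`: 2.48 ug/mL
compound 2, `N=C(N)c1ccc2[nH]c(-c3ccc4nc(-c5ccc(F)c(F)c5)[nH]c4c3)nc2c1`: 29.8 ug/mL
compound 3, `N=C(N)c1ccc2[nH]c(-c3ccc4nc(-c5ccccc5Oc5ccc(Cl)cc5)[nH]c4c3)nc2c1`: a limit of the assay, > 90 ug/mL

Compound 4, `N=C(N)c1ccc2[nH]c(-c3ccc4nc(-c5cc(F)ccc5Oc5ccc(Cl)cc5)[nH]c4c3)nc2c1`, is not yet measured. It differs from compound 3 by fluoro in place of hydrogen on an aromatic carbon. The same kind of change separates compound 1 from compound 2, (fluoro in place of hydrogen on an aromatic carbon), though there the place is ortho to a fluoro group, whereas in compound 4 it is para to a 4-chlorophenoxy group. That measured change gave a 12-fold higher number from compound 1 to compound 2 (1.08 log units; beyond the scatter). The difference between the core of compound 1 and the core of compound 3 is not broken down here. Among the measured compounds shown here, compound 3 sits at the limit of > 90 ug/mL in this assay, at which 1 of the 3 values shown sits, so no counted step can start from it. Because compound 3 is at the limit of > 90 ug/mL in this assay, at which 1 of the 3 values shown sits, compound 4 is expected to return a limit again, with an expected step that the limit leaves unreadable from compound 3 to compound 4 in this assay. Compound 4 is estimated at 110 ug/mL, between 45 ug/mL and 300 ug/mL.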

Compound 4, half-maximal inhibitory concentration: > 90 ug/mL
Compound 4 gave a limit, no number; the forecaster's own chance of this, stated with the estimate: 75%; the middle value lies beyond the limit too.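

Compound 3 and compound 4 both return a limit, not a number, in this assay, so no step between them can be read: the limit of > 90 ug/mL in this assay, at which 2 of the 4 values shown sit.

The compounds shown leave open whether fluoro in place of hydrogen, para to a 4-chlorophenoxy group, changes the read-out in this assay at all, and in which direction.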